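Swapping the Lactam Ring for Pyrrole on the Core

A few compounds are considered here, and "the series" means these few. Any claim that something is new, unique, unknown or untested is made for them only; others in the source may bear on it.

Among the measured compounds shown here, compound 2 `Cc1cc(N2CCCC2=O)c2ncc(CSCCc3ccccc3)n2c1` gives 20 ug/mL in an ADME assay on HEL cells (Homo sapiens) for cytotoxicity, with a stated time of 3 days (on this read-out lower numbers stand for higher toxicity in this test and higher numbers for lower toxicity in this test), the lowest of the two numbers so far; compound 1 `Cc1cc(-c2ccco2)c2ncc(CSCCc3ccccc3)n2c1` gives 100 ug/mL in this assay. For the measured compounds named here, the one measured step, a 5.0-fold lower number from compound 1 to compound 2 (0.70 log units; beyond the scatter), replaced a five-membered aromatic ring with 2-oxopyrrolidin-1-yl. Compound 3 `Cc1cc(-n2cccc2)c2ncc(CSCCc3ccccc3)n2c1` carries 1H-pyrrol-1-yl in place of 2-oxopyrrolidin-1-yl on an aromatic carbon. Going by the values given here, no step involving 1H-pyrrol-1-yl has been measured, but because the five-membered aromatic ring furan-2-yl in compound 1 gave 100 ug/mL, the number for compound 3 is expected to move back upward, a 2.5-fold higher number from compound 2 to compound 3 (0.40 log units; beyond the scatter). Compound 3 is therefore estimated at 50 ug/mL, within a range of 20 ug/mL to 100 ug/mL.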

Compound 3, minimum cytotoxic concentration: 100 ug/mL
The estimate for compound 3 lay 2.0-fold (0.30 log units) below the measured number, and the stated range covers the measured number.
By their numbers in this assay, from the lowest: compound 2; then compounds 1 and 3 (each within the scatter of the next).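

In this assay the step of a 5.0-fold higher number from compound 2 to compound 3 (0.70 log units; beyond the scatter) shows that, at this aromatic carbon, the lower number of compound 2 does not persist once 2-oxopyrrolidin-1-yl gives way to 1H-pyrrol-1-yl. Among the compounds shown here, the step of no change at the digits printed from compound 1 to compound 3 (within the scatter) means that furan-2-yl and 1H-pyrrol-1-yl, both five-membered aromatic rings, cannot be told apart in this test, leaving 2-oxopyrrolidin-1-yl the only group of the three that stands apart. Nothing available accounts for this difference.

Going by these compounds, whether a phenyl ring or a simple amine at this carbon would give a number like that of compound 3 remains open. So does whether 2-oxopyrrolidin-1-yl would lower the number again with a shorter chain on the sulfur.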